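A few compounds are considered here, and "the series" means these few. Any claim that something is new, unique, unknown or untested is made for them only; others in the source may bear on it.

Measured so far:
compound 1 `Cc1ccccc1/C(=N/NC(=S)NCCCCCC(=O)NO)c1ccccc1` gives 3510 nM
compound 2 `C/C(=N\NC(=S)NCCCCCC(=O)NO)c1ccc(F)cc1` gives 1890 nM

Both values come from a functional assay on K562 cells (Homo sapiens) for antiproliferative activity, read by MTT assay (a lower number here means a stronger inhibitor, a higher number a weaker inhibitor), and lie within the usual scatter of each other, so compound 1 stands level with compound 2 on the numbers at hand. Compound 3 `O=C(CCCCCNC(=S)N/N=C(\c1ccccc1)c1ccc([N+](=O)[O-])cc1)NO` has not yet been measured. Its difference from compound 1 is 4-nitrophenyl in place of 2-methylphenyl on a carbon with a double bond to nitrogen and in words it places 4-nitrophenyl in place of 2-methylphenyl on a carbon with a double bond to nitrogen. For the measured compounds named here, no step between measured compounds is available to size this change, so no shift beyond the scatter is expected in this assay in either direction. The estimated step is a 1.4-fold lower number from compound 1 to compound 3 (0.15 log units; within the scatter) on this reading. Compound 3 is expected at 2500 nM with an estimated range of 800 nM to 8000 nM for a single measurement.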

Compound 3, half-maximal inhibitory concentration: 2890 nM
For compound 3 the middle estimate is 1.2-fold (0.06 log units) below the measured one, within the range that was stated.
By their numbers in this assay, from the lowest: compounds 2, 3 and 1 (each within the scatter of the next).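

For the compounds shown here, the change from 2-methylphenyl to 4-nitrophenyl on a carbon with a double bond to nitrogen gives the first sized step at this place: in this assay it is a 1.2-fold lower number from compound 1 to compound 3 (0.08 log units; within the scatter). The entering group brings hydrogen-bond acceptors that the leaving group lacks, yet the two compounds stay within the scatter of each other, so this one exchange separates them by nothing that can be told from repeat error. No supporting measurement bears on this result.

As far as these compounds go, whether an amine or a carboxylic acid on this carbon would give a step beyond the scatter remains open, as does the effect of a longer chain in the shared core. Compound 2 differs from the others in more than one place, so steps to it cannot be read.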